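Chain-end change in a series held at a limit

A few compounds are considered here, and "the series" means these few. Any claim that something is new, unique, unknown or untested is made for them only; others in the source may bear on it.

Values in a functional assay on Jurkat cells (Homo sapiens) for cytotoxicity, with a stated time of 72 h (a higher number here means that more compound is needed for the effect, a lower number that less compound is needed), each a limit and not a number:
- compound 1 `C=C[C@@](C)(/C=C/c1ccc(O)cc1)CCCO`: > 49000 nM
- compound 2 `C=C[C@@](C)(/C=C/c1ccc(O)cc1)CC/C=C/C(=O)OCC`: > 49000 nM
- compound 3 `C=C[C@@](C)(/C=C/c1ccc(O)cc1)CC/C=C/C(=O)c1ccccc1`: > 49000 nM

Compound 2 has only a limit, > 49000 nM, and no number. The whole series shares one reading: the limit of > 49000 nM in this assay, at which 3 of the 3 values shown sit.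

Unmeasured compound 4 `C=C[C@@](C)(/C=C/c1ccc(O)cc1)CC/C=C(\C)C=O` carries 2-formylprop-1-en-1-yl in place of 2-(ethoxycarbonyl)ethenyl (2-formylprop-1-en-1-yl in place of 2-(ethoxycarbonyl)ethenyl on a saturated chain carbon, three bonds along the chain from two double-bonded chain carbons). Going by the values given here, two measured steps touch this group: a step that the two limits leave unreadable from compound 1 to compound 2 and a step that the two limits leave unreadable from compound 2 to compound 3. Neither gives a size, so no step beyond the scatter is expected in this assay, although the data cannot exclude one. The expected change is a step that the limit leaves unreadable from compound 2 to compound 4. For compound 4 the estimate is 50000 nM, with an expected range from 20000 nM to 80000 nM.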

Compound 4, half-maximal effective concentration: > 49000 nM
Compound 4 was reported as a limit; the forecaster's own chance of this, stated with the estimate: 70%; the middle value does not contradict the limit.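

Compound 4 is reported only as a limit, and the steps to it from compound 1 and compound 2 cannot be read. The compounds shown leave open what concentration any of them needs for the effect, and whether their chain-end groups differ at all.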